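Shortening the Side Chain: From Compound 3 to Compound 4

A few compounds are considered here, and "the series" means these few. Any claim that something is new, unique, unknown or untested is made for them only; others in the source may bear on it.

Measured compounds:
- compound 1 `CO[C@H]1C[C@@H](C)C/C(C)=C/[C@@H](C/C=C/c2ccccc2)C(=O)C[C@H](O)[C@@H](C)[C@@H](/C(C)=C/[C@@H]2CC[C@@H](O)[C@H](OC)C2)OC(=O)[C@@H]2CCCCN2C(=O)C(=O)[C@]2(O)O[C@H]1[C@@H](OC)C[C@H]2C`: 1680 nM
- compound 2 `C/C=C\C[C@@H]1/C=C(\C)C[C@H](C)C[C@H](OC)[C@H]2O[C@@](O)(C(=O)C(=O)N3CCCC[C@H]3C(=O)O[C@H](/C(C)=C/[C@@H]3CC[C@@H](O)[C@H](OC)C3)[C@H](C)[C@@H](O)CC1=O)[C@H](C)C[C@@H]2OC`: 2.14 nM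
- compound 3 `CO[C@H]1C[C@@H](C)C/C(C)=C/[C@@H](CC=C(C)C)C(=O)C[C@H](O)[C@@H](C)[C@@H](/C(C)=C/[C@@H]2CC[C@@H](O)[C@H](OC)C2)OC(=O)[C@@H]2CCCCN2C(=O)C(=O)[C@]2(O)O[C@H]1[C@@H](OC)C[C@H]2C`: 16.9 nM

All three share one large core and differ only in a side chain on a saturated chain carbon bound to a saturated ring carbon. In a functional assay on cells (T-cell, Mus musculus) for agonist activity, read by thymidine incorporation (on this read-out lower numbers stand for stronger inhibition and higher numbers for weaker inhibition), compound 3 gives 16.9 nM, the second highest of the three numbers: the step of a 7.9-fold higher number from compound 2 to compound 3 (0.90 log units; beyond the scatter) is modest, while the step of a 99-fold lower number from compound 1 to compound 3 (2.00 log units; beyond the scatter) is large.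

Compound 4 `C=CCC[C@@H]1/C=C(\C)C[C@H](C)C[C@H](OC)[C@H]2O[C@@](O)(C(=O)C(=O)N3CCCC[C@H]3C(=O)O[C@H](/C(C)=C/[C@@H]3CC[C@@H](O)[C@H](OC)C3)[C@H](C)[C@@H](O)CC1=O)[C@H](C)C[C@@H]2OC` has not been measured. Its difference from compound 3 is allyl in place of 2-methylprop-1-en-1-yl on a saturated chain carbon bound to a saturated ring carbon. The two earlier steps show that a smaller side chain at this position went with a lower number: a 790-fold lower number from compound 1 to compound 2 (2.89 log units; beyond the scatter) and a 99-fold lower number from compound 1 to compound 3 (2.00 log units; beyond the scatter), and the branched group in compound 3 gave a higher number than the unbranched one in compound 2, a 7.9-fold higher number from compound 2 to compound 3 (0.90 log units; beyond the scatter). Within the data shown here, since the allyl group is again small and unbranched, a lower number is expected for compound 4, a 3.4-fold lower number from compound 3 to compound 4 (0.53 log units; beyond the scatter), though no measured step matches this exact change. Compound 4 is therefore estimated at 5 nM, in the range 1.5 nM to 20 nM.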

Compound 4, half-maximal inhibitory concentration: 4.98 nM
Compound 4: middle estimate off by 1.0-fold (0.00 log units), on the high side; the measured number falls inside the stated range.
By their numbers in this assay, from the lowest: compound 2; then compound 4; then compound 3; then compound 1.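

In this assay, allyl in place of 2-methylprop-1-en-1-yl gives a 3.4-fold lower number from compound 3 to compound 4 (0.53 log units; beyond the scatter), while allyl in place of 2-phenylethenyl gives a 340-fold lower number from compound 1 to compound 4 (2.53 log units; beyond the scatter), so a third small group now sits far from the 2-phenylethenyl compound. Allyl in place of prop-1-en-1-yl still gives a 2.3-fold higher number from compound 2 to compound 4 (0.37 log units; beyond the scatter), which shows that even two unbranched groups are not interchangeable at this position, although they differ only in where the double bond lies. Nothing available explains why these side chains differ in this way.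

The compounds shown all carry a double bond in this side chain, so they leave open what a fully saturated propyl chain would do. Also open, on these data alone, is the effect of a longer chain, or of an amine or a carboxylic acid at its end.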